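Working notes: replacing the cyano group

The compounds below may be only part of what the source reports. "The series", "measured", "known", "first", "only" and "open" are said of these compounds alone.

Of the compounds shown here, two sharing one core have been measured so far in a functional assay on MCF7 cells (Homo sapiens) for antiproliferative activity, read by cell counting, with a stated time of 4 days; on this read-out higher numbers stand for weaker inhibition and lower numbers for stronger inhibition. Compound 1 (`CCOC(=O)CN(Cc1ccc(F)cc1)c1ccc2c(c1)OC(C)(COc1ccc(C#N)cc1)CN2C`) gives > 100000 nM, which is a limit of the assay and not a number. Compound 2 (`CCOC(=O)CN(Cc1cc(F)cc(F)c1)c1ccc2c(c1)N(C)CC(C)(COc1ccc(C#N)cc1)O2`) gives > 100000 nM, which is also a limit and not a number. Compound 2 therefore offers no numerical starting point, and the record so far is the limit of > 100000 nM in this assay, at which 2 of the 2 values shown sit.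

Compound 3 (`CCOC(=O)CN(Cc1cc(F)cc(F)c1)c1ccc2c(c1)N(C)CC(C)(COc1ccc(C(=N)N)cc1)O2`) differs from compound 2 in one place, on an aromatic carbon para to a large group: a group of 3 heavy atoms (1 carbon, 2 nitrogen; no ring) in place of a group of 2 heavy atoms (1 carbon, 1 nitrogen; no ring), on an aromatic carbon. Within the data shown here, no measured step covers this change, so what follows is an expectation with little support from the data. The expected change is an at least 3.3-fold lower number from compound 2 to compound 3 (0.52 log units; beyond the scatter), in the direction of stronger inhibition, and it is likely to be modest. A result that stays at the limit remains a real possibility. For compound 3 the estimate is 30000 nM, with an expected range from 5000 nM to 100000 nM.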

Compound 3, half-maximal inhibitory concentration: 4500 nM
Compound 3: the middle estimate sits 6.7-fold (0.82 log units) above what was measured; measured number outside the range, below it.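

Among these compounds, on an aromatic carbon para to a large group, the cyano group gives way to a group of 3 heavy atoms (1 carbon, 2 nitrogen; no ring), and this single change yields the first number in this assay: an at least 22-fold lower number from compound 2 to compound 3 (1.34 log units; beyond the scatter). For compound 2, > 100000 nM is a limit and not a number, so the step has a lower bound only and its full size cannot be read. Compound 3 gives 4500 nM, which shows that a change at this position can give the series a measured number. The earlier compounds could not show this, as the record stands: the limit of > 100000 nM in this assay, at which 2 of the 3 values shown sit.

Going by these compounds, it remains open whether the entering group is specifically required, or whether another group on the same carbon, such as a primary amine, a primary amide or a carboxylic acid, would also give a number in this assay. Among the compounds shown here, it also remains open whether the same change would bring a similar step on the core of compound 1, since the only step available comes from the pair above.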